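Methoxy Added to the Phenol of a Bis-chalcone Piperazine

This account rests on a few compounds, and the source may have more. Where it says the series, first, only, none or still open, it means among the compounds named here.

Measured compounds:
compound 1 `O=C(/C=C/c1ccccn1)c1ccc(N2CCN(Cc3cc(C(=O)/C=C/c4ccccn4)ccc3O)CC2)cc1` — 1260 nM
compound 2 `O=C(/C=C/c1cccs1)c1ccc(N2CCN(Cc3cc(C(=O)/C=C/c4cccs4)ccc3O)CC2)cc1` — > 37000 nM

The study uses a functional assay on HCT-8 cells (Homo sapiens) for cytotoxicity, with a stated time of 3 days; on this read-out lower numbers stand for stronger inhibition of growth and higher numbers for weaker inhibition of growth. In this assay compound 1 gives 1260 nM. Compound 2 gives > 37000 nM in this assay, and this value is a limit of the assay, not a number. Among the compounds with values here, compound 1 therefore stands alone as the only compound with a measured number; the other value shown is the limit (the limit of > 37000 nM in this assay, at which 1 of the 2 values shown sits).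

Compound 3 `COc1cc(C(=O)/C=C/c2ccccn2)cc(CN2CCN(c3ccc(C(=O)/C=C/c4ccccn4)cc3)CC2)c1O` has not been measured. It differs from compound 1 by methoxy in place of hydrogen on an aromatic carbon. Within the data shown here, no measured pair in this set shows the effect of such a change. The step from compound 1 to compound 3 in this assay is expected to be small, without a clear direction beyond the scatter.

Compound 3 is estimated at 1000 nM, with a range from 400 nM to 3000 nM, so the expected step is a 1.3-fold lower number from compound 1 to compound 3 (0.10 log units; within the scatter).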

Compound 3, concentration for 50% growth inhibition: 700 nM
Beside the measured number, compound 3's estimate is 1.4-fold (0.15 log units) above it; measured number inside the range.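

In this assay, within the data shown here, methoxy in place of hydrogen on an aromatic carbon, ortho to a hydroxy group and meta to a (2-(pyridin-2-yl)ethenyl)carbonyl group, gives a 1.8-fold lower number from compound 1 to compound 3 (0.26 log units; within the scatter) in the first measured pair to read such a change. At this position, therefore, the methoxy group brings no shift beyond the scatter, and compound 3 and compound 1 cannot be told apart on this read-out. Nothing in the data shown accounts for this result.

What the compounds shown leave open is whether an ethoxy group, a dimethylamino group or a carboxylic acid at this same position would also leave the read-out within the scatter. This single pair also cannot say how a methoxy group would read elsewhere on the core of compound 1.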